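Aryl swaps on the shared core

The source may report more compounds than this note shows. Statements on the series, on what has been measured and on what is new or still open speak of the compounds shown alone.

Measured so far:
compound 1 `CCCCCCCCCCCCCCCCCCNC(=O)[C@H]1CSC(c2c[nH]c3ccccc23)N1` gives 8900 nM in a functional assay on DU-145 cells (Homo sapiens) for antiproliferative activity, read by sulforhodamine B assay; on this read-out lower numbers stand for stronger inhibition and higher numbers for weaker inhibition
compound 2 `CCCCCCCCCCCCCCCCCCNC(=O)[C@H]1CSC(c2cccc(O)c2)N1` gives 5700 nM
compound 3 `CCCCCCCCCCCCCCCCCCNC(=O)[C@H]1CSC(c2cc(F)cc(F)c2)N1` gives > 20000 nM

Compound 3 reaches only the assay limit > 20000 nM in this assay, a limit and not a number. Against compound 1 and compound 2 it stands weakest, as the steps of an at least 2.2-fold higher number from compound 1 to compound 3 (0.35 log units; beyond the scatter) and an at least 3.5-fold higher number from compound 2 to compound 3 (0.54 log units; beyond the scatter) show, both exchanges of the aryl on the same saturated ring carbon. Compound 4 `CCCCCCCCCCCCCCCCCCNC(=O)[C@H]1CSC(c2ccc(F)c(Br)c2)N1` carries 3-bromo-4-fluorophenyl in place of 3,5-difluorophenyl on a saturated ring carbon. Here one halogenated phenyl replaces another, and no measured step covers such a swap directly; the two steps onto compound 3 both pointed to higher numbers, so no step beyond the scatter is expected in this assay. Compound 4 is estimated at 18000 nM, between 7000 nM and 40000 nM. The expected step is an at least 1.1-fold lower number from compound 3 to compound 4 (0.04 log units; that floor lies within the scatter), with a fair chance that only a limit is again returned.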

Compound 4, half-maximal inhibitory concentration: 11300 nM
Compound 4: the middle estimate sits 1.6-fold (0.20 log units) above what was measured; the measured number falls inside the stated range.
By their numbers in this assay, from the lowest: compounds 2, 1 and 4 (each within the scatter of the next). At a limit, above all of these: compound 3.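

A halogenated phenyl on this saturated ring carbon can return a number in this assay, so halogen substitution alone does not send a compound of this series to the limit. Compound 3 remains a limit and not a number, so an at least 1.7-fold lower number from compound 3 to compound 4 (0.24 log units; that floor lies within the scatter) gives only a floor: the limit of > 20000 nM in this assay, at which 1 of the 4 values shown sits. The other two exchanges, a 2.0-fold higher number from compound 2 to compound 4 (0.30 log units; within the scatter) and a 1.3-fold higher number from compound 1 to compound 4 (0.10 log units; within the scatter), leave compound 1, compound 2 and compound 4 unordered.

The compounds shown do not separate the kind of halogen from its placement on the phenyl. Still open, from the compounds shown here alone, is how a 3-aminophenyl or a pyridine at this carbon, or a shorter chain on the amide, would read.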